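A Methyl Added to the Benzamide of Compound 2

The compounds below may be only part of what the source reports. "The series", "measured", "known", "first", "only" and "open" are said of these compounds alone.

Measured so far in an assay on LtK cells with ATP-sensitive inward rectifier potassium channel 11 (Homo sapiens) as the target; on this read-out higher numbers stand for an effect only at larger amounts of compound and lower numbers for an effect already at smaller amounts:
Compound 1 `COCC(=O)Nc1c(C(O)(C(F)(F)F)C(F)(F)F)ccc2ccccc12`: 213 nM
Compound 2 `O=C(Nc1c(C(O)(C(F)(F)F)C(F)(F)F)ccc2ccccc12)c1ccccc1`: 44 nM

Among the compounds with values here, compound 2 holds the lower of these two numbers, and the gap to compound 1, the only other compound measured, is beyond the scatter. Within the data shown here, the single measured step, a 4.8-fold lower number from compound 1 to compound 2 (0.68 log units; beyond the scatter), came from putting phenyl in place of methoxymethyl on a carbonyl carbon, a modest change in the direction of an effect at smaller amounts.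

Compound 3 `Cc1ccccc1C(=O)Nc1c(C(O)(C(F)(F)F)C(F)(F)F)ccc2ccccc12` keeps the phenyl of compound 2 and differs from it only by methyl in place of hydrogen on an aromatic carbon of a six-membered aromatic ring of carbon only, ortho to a large group. Among the measured compounds shown here, no measured step touches that ring; the one step measured concerns the group on the carbonyl carbon itself, so nothing measured bears directly on this change. With no evidence either way, the step of a 1.1-fold higher number from compound 2 to compound 3 (0.06 log units; within the scatter) is expected to stay within the scatter. Compound 3 is therefore estimated at 50 nM, with a range of 15 nM to 160 nM.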

Compound 3, half-maximal effective concentration: 5550 nM
Compound 3: the middle estimate sits 110-fold (2.05 log units) below what was measured; measured number outside the range, above it.
By their numbers in this assay, from the lowest: compound 2; then compound 1; then compound 3.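

Compound 2's phenyl ring is clearly not indifferent to substitution: in this assay, a single methyl in place of hydrogen on an aromatic carbon, ortho to a large group, gives a 130-fold higher number from compound 2 to compound 3 (2.10 log units; beyond the scatter), a large step from a change of only one heavy atom. The gain seen earlier with phenyl does not survive this methyl. The result for 2-methylphenyl in place of methoxymethyl on the carbonyl carbon, a 26-fold higher number from compound 1 to compound 3 (1.42 log units; beyond the scatter), runs opposite to the earlier step, a 4.8-fold lower number from compound 1 to compound 2 (0.68 log units; beyond the scatter). Compound 3 goes against any simple reading that an aromatic ring on the carbonyl carbon lowers the number. Nothing available explains why one methyl has so large an effect on this read-out.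

The compounds shown leave open whether this loss belongs to methyl alone or would also appear with a fluorine, a chlorine or a methoxy group at the same place. As far as these compounds go, it also remains open how the ring would respond to a methyl on one of its other carbons, or to an amine or a carboxylic acid there.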